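The source may report more compounds than this note shows. Statements on the series, on what has been measured and on what is new or still open speak of the compounds shown alone.

Two compounds of a shared core, compound 1, `CC(C)N(Cc1cccc(OCCCCCC(=O)O)c1)C(=O)c1ccc(-c2ccsc2)cc1`, and compound 2, `CC(C)N(Cc1cccc(OCCCCCC(=O)O)c1)C(=O)c1ccc(-c2ccc(Cl)c(Cl)c2)cc1`, have been measured in an ADME assay on Raji cells (Homo sapiens) for cytotoxicity, read by CellTiter-Glo and resazurin assay, with a stated time of 72 h; a higher number here means that more compound is needed for the effect, a lower number that less compound is needed. In this assay compound 1 gives > 26000 nM, which is a limit of the assay and not a number. Compound 2 gives > 26000 nM, likewise a limit. The step that the two limits leave unreadable from compound 1 to compound 2 therefore cannot be read. Compound 2 thus stands at the limit of > 26000 nM in this assay, at which 2 of the 2 values shown sit, with no numerical value of its own and nothing to set it apart from compound 1.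

Compound 3, `CC(C)N(Cc1cccc(OCCCCCC(=O)O)c1)C(=O)c1ccc(-c2cccc(S(C)(=O)=O)c2)cc1`, differs from compound 2 by 3-(methylsulfonyl)phenyl in place of 3,4-dichlorophenyl on an aromatic carbon. Within the data shown here, the only measured step, a step that the two limits leave unreadable from compound 1 to compound 2, concerns a change at the same place but offers no size to carry over; the two values show only that neither compound reaches the cutoff. For compound 3 the expected step that the limit leaves unreadable from compound 2 to compound 3 in this assay is none that could be seen, as the measured values stop at the same limit. Compound 3 is accordingly estimated at 40000 nM, within a range of 15000 nM to 100000 nM, and it is expected that this assay will most likely again report only a limit.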

Compound 3, half-maximal effective concentration: > 26000 nM
Compound 3 gave a limit, no number; the forecaster's own chance of this, stated with the estimate: 85%; the middle value does not contradict the limit.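

Compound 1, compound 2 and compound 3 all end at a limit and not a number in this assay, and no step between them can be read: the limit of > 26000 nM in this assay, at which 3 of the 3 values shown sit.

The compounds shown leave open how far past that limit each of them lies, and whether any group at this place on the shared core would give a readable value in this assay.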